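The compounds below may be only part of what the source reports. "The series", "measured", "known", "first", "only" and "open" are said of these compounds alone.

Compound 1 `Cc1c(Nc2nc(N)c3c(C#N)c(N4CCC[C@H]4C)n(C)c3n2)cnn1C` is measured in an assay on isolated protein for inhibition of Leucine-rich repeat serine/threonine-protein kinase 2 variant G2019S (Homo sapiens), read by TR-FRET and LanthaScreen, with stated times of 50 min and 30 min, in the presence of a further agent that is not named here (on this read-out lower numbers stand for stronger inhibition and higher numbers for weaker inhibition), where compound 1 gives 43 nM. This is the higher of the two numbers recorded. Among the compounds with values here, its only neighbour, compound 2 `C[C@@H]1CCCN1c1c(C#N)c2c(N)ncnc2n1C`, carries hydrogen in place of the (1,5-dimethyl-1H-pyrazol-4-yl)amino group on the aromatic carbon; in this assay compound 2 gives 11 nM, so that a 3.9-fold lower number from compound 1 to compound 2 (0.59 log units; beyond the scatter).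

Compound 3 `Cc1c(Nc2nc(N)c3c(C#N)c(N4CCC[C@H]4C)n(C)c3n2)cnn1CC1(O)COC1` keeps the whole of compound 1 and differs from it in one place only: 3-hydroxyoxetan-3-yl in place of hydrogen on a saturated chain carbon bound to an aromatic nitrogen. Within the data shown here, the single measured step concerns a different part of the molecule, the removal of the whole pyrazolylamino group, and it speaks to the new change only indirectly: it shows that altering that side of compound 1 moved the number by a modest amount. Among the measured compounds shown here, no measured pair shows what a substituent on the methyl group bound to the aromatic nitrogen does. The expectation is therefore a step that stays within the usual scatter in this assay, in either direction, and the expected step is a 1.1-fold lower number from compound 1 to compound 3 (0.03 log units; within the scatter). Compound 3 is estimated at 40 nM, with a range from 15 nM to 120 nM.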

Compound 3, half-maximal inhibitory concentration: 10 nM
Estimate against measurement, compound 3: 4.0-fold (0.60 log units) above; measured number below the stated range.
By their numbers in this assay, from the lowest: compounds 3 and 2 (each within the scatter of the next); then compound 1.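

In this assay, extending methyl to (3-hydroxyoxetan-3-yl)methyl gives a 4.3-fold lower number from compound 1 to compound 3 (0.63 log units; beyond the scatter). Within the data shown here, the earlier step removed the whole (1,5-dimethyl-1H-pyrazol-4-yl)amino group, whereas this pair is the first to probe the saturated chain carbon bound to an aromatic nitrogen: it shows that this place accepts a substituent of 5 heavy atoms, including a four-membered ring, and that the number falls beyond the scatter rather than rises. Nothing given here explains why the number moved.

The change brings in the ring and the hydroxyl together, so the compounds shown leave open whether the step depends on the whole 3-hydroxyoxetan-3-yl group or on only one part of it. A plain hydroxymethyl group, an oxetan-3-yl group without the hydroxyl, a longer chain ending in an amine or a carboxylic acid at this place would each help separate these possibilities, and the result so far rests on this single pair in this one assay.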